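Series notes: from compound 2 to compound 3

This account rests on a few compounds, and the source may have more. Where it says the series, first, only, none or still open, it means among the compounds named here.

Measured so far:
compound 1, `COc1ccccc1C(=O)Nc1cccc(NC(=O)c2ccc(Cl)c(Cl)c2)c1`: > 30000 nM
compound 2, `COc1ccccc1C(=O)Nc1cccc(NC(=O)c2ccc(F)cc2)c1`: > 30000 nM

In an in vitro functional assay on HEK293-A cells for antagonist activity at metabotropic glutamate receptor 5 (Rattus norvegicus), read by calcium flux (on this read-out higher numbers stand for weaker inhibition and lower numbers for stronger inhibition), compound 1 gives > 30000 nM, a limit of the assay and not a number. In this assay compound 2 gives > 30000 nM, likewise a limit. The step that the two limits leave unreadable from compound 1 to compound 2 is thus unreadable; (the limit of > 30000 nM in this assay, at which 2 of the 2 values shown sit). Compound 3 is `COc1ccccc1C(=O)Nc1cccc(NC(=O)c2cccc(C#N)c2)c1`, differing from compound 2 by 3-cyanophenyl in place of 4-fluorophenyl on a carbonyl carbon. No readable measured step bears on this change. For compound 3 the step of a number no higher from compound 2 to compound 3 (the limit leaves the size open) in this assay is expected to be none beyond the scatter, most likely again a limit. Compound 3 is estimated at 30000 nM, range 8000 nM to 100000 nM.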

Compound 3, half-maximal inhibitory concentration: 1800 nM
Beside the measured number, compound 3's estimate is 17-fold (1.22 log units) above it; the whole stated range lies above it.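

The group on this carbonyl carbon decides whether inhibition can be read at all in this assay: 3-cyanophenyl gives an at least 16-fold lower number from compound 2 to compound 3 (1.22 log units; beyond the scatter), and set against 3,4-dichlorophenyl it gives an at least 16-fold lower number from compound 1 to compound 3 (1.22 log units; beyond the scatter). Among these compounds, compound 3 thus gives the first value of the series that is not a limit. Both sizes are therefore floors, and the step between the two compounds at the limit cannot be read: the limit of > 30000 nM in this assay, at which 2 of the 3 values shown sit.

On these data alone, it remains open whether the nitrile alone accounts for these steps. Also open, as far as these compounds go, is whether an amine or a carboxylic acid on the same phenyl ring would serve as well.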